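Working notes: trimming ethyl to methyl, compound 3 to compound 4

The source may hold more compounds than are shown below. What is called first, only, known or untested is meant among the compounds shown, and "the series" means these compounds.

Compounds measured so far in an ADME assay on HaCaT cells (Homo sapiens) for inhibition, read by sulforhodamine B assay, with a stated time of 48 h; a higher number here means a weaker inhibitor of growth, a lower number a stronger inhibitor of growth:
- compound 1 `S=C(N/N=C/c1cccs1)Nc1ccccc1` — > 100000 nM (a limit of the assay, not a number)
- compound 2 `S=C(N/N=C/c1cccs1)Nc1cccc2ccccc12` — 82400 nM
- compound 3 `CCc1ccc(NC(=S)N/N=C/c2cccs2)cc1` — 17600 nM
- compound 4 `Cc1ccc(NC(=S)N/N=C/c2cccs2)cc1` — not yet measured

Compound 1 gives only a limit in this assay, namely > 100000 nM. Compound 2 gives 82400 nM. Compound 3 gives 17600 nM, the lowest of the two numbers shown, and compound 2 stands nearest to it. The one further entry, that of compound 1, is a limit of the assay.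

Within the data shown here, only one measured step bears on the trimming in question: an at least 5.6-fold lower number from compound 1 to compound 3 (0.75 log units; beyond the scatter). Compound 4 differs from compound 3 by hydrogen in place of methyl on a saturated chain carbon bound to an aromatic carbon, so it stands between compound 1 and compound 3 in that respect. Since an at least 5.6-fold lower number from compound 1 to compound 3 (0.75 log units; beyond the scatter) was at least modest, removing one carbon of the ethyl is expected to give back part of that step, so a rise beyond the scatter is expected, a 2.2-fold higher number from compound 3 to compound 4 (0.33 log units; beyond the scatter). Compound 4 is therefore estimated at 38000 nM, within 12000 nM to 100000 nM.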

Compound 4, concentration for 50% growth inhibition: 17600 nM
For compound 4 the middle estimate is 2.2-fold (0.33 log units) above the measured one, within the range that was stated.
By their numbers in this assay, from the lowest: compounds 3 and 4 (each within the scatter of the next); then compound 2. At a limit, above all of these: compound 1.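

In this assay, the step reads no change at the digits printed from compound 3 to compound 4 (within the scatter), so the outer carbon of the ethyl makes no difference that can be read here. Methyl in place of hydrogen on an aromatic carbon already gives an at least 5.6-fold lower number from compound 1 to compound 4 (0.75 log units; beyond the scatter), so the gain first seen with ethyl does not depend on the longer of the two groups. The size of that gain remains only a lower bound, because compound 1 stands at a limit of the assay: the limit of > 100000 nM in this assay, at which 1 of the 4 values shown sits.

As far as these compounds go, whether a longer chain such as butyl, or an amine or a carboxylic acid in place of the methyl, would keep the number of compound 4 remains open. Also open, from the compounds shown here alone, is whether methyl and ethyl would read alike on a core other than that of compound 1.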